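Truncating the acyl chain on the amide of compound 3

A few compounds are considered here, and "the series" means these few. Any claim that something is new, unique, unknown or untested is made for them only; others in the source may bear on it.

Three compounds of the series have been run in an assay for inhibition of casein kinase I isoform alpha (Sus scrofa), read by scintillation counting and 33P incorporation, with a stated time of 30 min, in the presence of a further agent that is not named here (a higher number here means a weaker inhibitor, a lower number a stronger inhibitor), and none of them returned a number. Compound 1 `CCCNc1cc(-c2ccccc2)c(=O)[nH]n1` gives > 10000 nM in this assay, a limit of the assay rather than a value. Compound 2 `CC(=O)N(C(C)=O)c1n[nH]c(=O)c2ccccc12` likewise gives only the limit, > 10000 nM. Compound 3 `CCCCCC(=O)Nc1n[nH]c(=O)c2ccccc12` gives > 10000 nM, again a limit and not a measured potency. Compound 3 therefore stands with the other two at the assay ceiling (the limit of > 10000 nM in this assay, at which 3 of the 3 values shown sit), and no ordering among the three can be drawn.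

Compound 4 `CC(=O)Nc1n[nH]c(=O)c2ccccc12` differs from compound 3 by hydrogen in place of butyl on a saturated chain carbon bound to a carbonyl carbon. Within the data shown here, no step between measured compounds exists to size this change, and compound 3 sits at a limit, so no number is available from which a shift could be read. The step expected in this assay is a step that the limit leaves unreadable from compound 3 to compound 4, none beyond the scatter in either direction. Compound 4 is thus estimated to remain at the ceiling, at 30000 nM, with a range from 8000 nM to 100000 nM.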

Compound 4, half-maximal inhibitory concentration: > 10000 nM
Compound 4 ended at the assay's limit (the forecaster's own chance of this, stated with the estimate: 85%); the middle value does not contradict the limit.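

In this assay compound 4 gives > 10000 nM, a limit and not a measured potency. No step to it can be read from compound 2 or compound 3, all three standing at the ceiling: the limit of > 10000 nM in this assay, at which 4 of the 4 values shown sit.

The compounds shown leave open which structural change, if any, would bring a measurable potency and how these four rank.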